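The compounds below may be only part of what the source reports. "The series", "measured", "known", "first", "only" and "open" are said of these compounds alone.

In a functional assay on A549 cells (Homo sapiens) for inhibition, read by sulforhodamine B assay, with a stated time of 48 h, tested at 50 uM (on this read-out lower numbers stand for less inhibition of growth and higher numbers for more inhibition of growth at the one concentration tested), compound 1 `CCCOc1ccc([C@@H]2CC(=O)c3cc(CC=C(C)C)c(OC)cc3O2)cc1` gives 43%. Compound 2 `COc1ccc([C@@H]2C/C(=N/OCc3cn(-c4ccc(C#N)cc4)nn3)c3cc(CC=C(C)C)c(OC)cc3O2)cc1` gives 42%, within the scatter of compound 1, while compound 3 `COc1cc2c(cc1CC1OC1(C)C)C(=O)C[C@@H](c1ccc(O)cc1)O2` gives 79%, beyond the scatter and higher than compound 1. Compound 4 `COc1cc2c(cc1CC=C(C)C)C(=O)C[C@@H](c1ccc(Oc3cccc([N+](=O)[O-])c3)cc1)O2` has not yet been measured. It carries 3-nitrophenyl in place of propyl on an oxygen on an aromatic ring. Within the data shown here, no measured pair of compounds differs in one place only, so the data offer no direct guide to this change. The expected shift is therefore none beyond the scatter, and the estimated step is a number 2 percentage points higher from compound 1 to compound 4 (within the scatter). For compound 4 the expected value is 45%, with an estimated range from 27% to 63%.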

Compound 4, percent growth inhibition at one concentration: 37%
The estimate for compound 4 lay 8 percentage points above the measured number; measured number inside the range.
By their numbers in this assay, from the lowest: compounds 4, 2 and 1 (each within the scatter of the next); then compound 3.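

Among these compounds, this is the first pair in this assay that differs in one place, and it gives a direct reading for an oxygen on an aromatic ring: replacing propyl with 3-nitrophenyl gives a number 6 percentage points lower from compound 1 to compound 4 (within the scatter). Thus, in this core, propoxy and 3-nitrophenoxy cannot be told apart at the one concentration tested, even though the new group brings an aromatic ring and a nitro group.

The compounds shown leave open whether a longer chain in place of propyl, or an amine or a carboxylic acid in place of the nitro group, would read differently. Nothing measured here offers an explanation for this result.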